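The source may report more compounds than this note shows. Statements on the series, on what has been measured and on what is new or still open speak of the compounds shown alone.

Compound 1 `O=C(CCc1ccc(Cl)cc1)C(=O)N1CCCCC1` carries a piperidine amide on the shared core. In an assay on HEK-293T cells for inhibition of phospholipase A and acyltransferase 2 (Homo sapiens), with stated times of 30 min and 20 min (on this read-out lower numbers stand for stronger inhibition and higher numbers for weaker inhibition), compound 1 gives > 10000 nM, which is a limit of the assay rather than a number. Compound 3 `O=C(CCc1ccc(Cl)cc1)C(=O)N1CCCC1` differs by piperidin-1-yl in place of pyrrolidin-1-yl on a carbonyl carbon. In this assay compound 3 gives > 10000 nM, again a limit. The step that the two limits leave unreadable from compound 1 to compound 3 therefore cannot be sized. Compound 2 `O=C(CCc1ccc(Cl)cc1)C(=O)N1CC[C@@H](c2ccccc2)C1` arises from compound 3 through (phenyl in place of hydrogen on a saturated ring carbon). In this assay compound 2 gives > 10000 nM, also a limit, so the step that the two limits leave unreadable from compound 3 to compound 2 is likewise unreadable.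

Compound 4 `O=C(CCc1ccc(Cl)cc1)C(=O)N1CCCC[C@H]1c1ccccc1`, not yet measured, follows from compound 1 through (phenyl in place of hydrogen on a saturated ring carbon). The same kind of change as from compound 3 to compound 2, yet not the same: here the phenyl sits on a six-membered ring, next to the ring nitrogen, whereas in compound 2 it sits on a five-membered ring, two ring bonds from the ring nitrogen. The expected step that the limit leaves unreadable from compound 1 to compound 4 rests on (the limit of > 10000 nM in this assay, at which 3 of the 3 values shown sit). Compound 4 is expected to give about 15000 nM, estimated between 5000 nM and 50000 nM.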

Compound 4, half-maximal inhibitory concentration: > 10000 nM
Compound 4: no number, only a limit; the forecaster's own chance of this, stated with the estimate: 80%; the middle value does not contradict the limit.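

Compound 1 and compound 4 both stand at a limit of the assay rather than a number, so the step between them cannot be read. The compounds shown leave open how strongly any of these changes on the shared core affects inhibition, with only this to go on: the limit of > 10000 nM in this assay, at which 4 of the 4 values shown sit.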